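The compounds below may be only part of what the source reports. "The series", "measured", "known", "first", "only" and "open" are said of these compounds alone.

Measured so far in a functional assay on HT-29 cells (Homo sapiens) for inhibition, read by sulforhodamine B assay, with a stated time of 48 h; a lower number here means a stronger inhibitor of growth, a higher number a weaker inhibitor of growth:
compound 1 `O=C(Nc1cccc(-n2cc(-c3ccncc3)c(-c3ccc(Cl)c(O)c3)n2)c1)Nc1cccc(C(F)(F)F)c1` gives 9820 nM
compound 2 `O=C(Nc1cccc(-n2cc(-c3ccncc3)c(-c3ccc(Cl)c(O)c3)n2)c1)Nc1ccc(Cl)c(Cl)c1` gives 4890 nM

Compound 1 holds the upper of the two numbers in this assay, though the step of a 2.0-fold lower number from compound 1 to compound 2 (0.30 log units; within the scatter) lies within the scatter. Compound 3 `O=C(Nc1cccc(-n2cc(-c3ccncc3)c(-c3ccc(Cl)c(O)c3)n2)c1)Nc1cc(C(F)(F)F)cc(C(F)(F)F)c1` differs from compound 1 by trifluoromethyl in place of hydrogen on an aromatic carbon. For the measured compounds named here, the only step that bears on this change is the exchange of the same aryl group from compound 1 to compound 2, a 2.0-fold lower number from compound 1 to compound 2 (0.30 log units; within the scatter), within the scatter; no step beyond the scatter is therefore expected, a 1.2-fold lower number from compound 1 to compound 3 (0.09 log units; within the scatter). Compound 3 is estimated at 8000 nM, in a range from 3000 nM to 25000 nM.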

Compound 3, concentration for 50% growth inhibition: 746 nM
For compound 3 the middle estimate is 11-fold (1.03 log units) above the measured one, outside the stated range (below it).
By their numbers in this assay, from the lowest: compound 3; then compounds 2 and 1 (each within the scatter of the next).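

In this assay, trifluoromethyl in place of hydrogen on this aromatic carbon, meta to a trifluoromethyl group, gives a 13-fold lower number from compound 1 to compound 3 (1.12 log units; beyond the scatter). For the compounds shown here, the earlier exchange of aryl groups, a 2.0-fold lower number from compound 1 to compound 2 (0.30 log units; within the scatter), showed no change beyond the scatter, so this is the first sign that substitution on this ring can move the number substantially. Nothing available explains the size of this step.

Trifluoromethyl is the only group shown on this carbon. As far as these compounds go, whether a methoxy group or an amine there would give a similar step stays open.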